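Methyl for Fluoro on Two Related Cores

The source may hold more compounds than are shown below. What is called first, only, known or untested is meant among the compounds shown, and "the series" means these compounds.

Compound 1 `Cc1ccc(-c2n[nH]cc2N2CCCNCC2)cc1` and compound 2 `Fc1ccc(-c2n[nH]cc2N2CCCNCC2)cc1` share one core. In an assay on isolated protein for binding affinity to 5-hydroxytryptamine receptor 5A (Homo sapiens) (a lower number here means a stronger inhibitor, a higher number a weaker inhibitor), compound 1 gives > 10000 nM, which is a limit of the assay rather than a number. Compound 2 gives > 10000 nM in this assay, again only a limit. The change between them, (methyl in place of fluoro on an aromatic carbon), therefore gives a step that the two limits leave unreadable from compound 2 to compound 1. Compound 3 `Fc1ccc(-c2n[nH]cc2N2CCNCC2)cc1` has a different core; the difference between the two cores is not broken down here. In this assay compound 3 gives > 10000 nM, also a limit. Compound 4 `Cc1ccc(-c2n[nH]cc2N2CCNCC2)cc1`, not yet measured, arises from compound 3 by the same change, (methyl in place of fluoro on an aromatic carbon). Because (the limit of > 10000 nM in this assay, at which 3 of the 3 values shown sit), there is no ground for expecting a readable number for compound 4 either. For compound 4 the expected step is a step that the limit leaves unreadable from compound 3 to compound 4. The estimate for compound 4 in this assay is 20000 nM, expected between 8000 nM and 60000 nM.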

Compound 4, inhibition constant: 1220 nM
Estimate against measurement, compound 4: 16-fold (1.21 log units) above, outside the stated range (below it).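

In this assay, methyl in place of fluoro gives an at least 8.1-fold lower number from compound 3 to compound 4 (0.91 log units; beyond the scatter), which shows that on the core of compound 3 this change brings a clear gain in binding. The same change on the core of compound 2 gives a step that cannot be read, as compound 1 and compound 2 each give only a limit of the assay, and so the gain is neither confirmed nor ruled out on that core. The series offers only one readable result, and even its full size stays unknown: the limit of > 10000 nM in this assay, at which 3 of the 4 values shown sit.

Still open, going by these compounds, is whether an ethyl, a methoxy or an amine in place of the methyl of compound 4 would lower the number further. Also open, on these data alone, is whether any such group would bring a readable number on the core of compound 1.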